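This account rests on a few compounds, and the source may have more. Where it says the series, first, only, none or still open, it means among the compounds named here.

The measured compounds and their values in a functional assay on M14 cells (Homo sapiens) for inhibition, read by sulforhodamine B assay, with a stated time of 48 h; a lower number here means a stronger inhibitor of growth, a higher number a weaker inhibitor of growth:
Compound 1, `Nc1cc(N)c2nc(-c3ccccc3)c(NCc3ccc(F)cc3)nc2c1`, gives 23400 nM.
Compound 3, `Nc1cc(N)c2nc(-c3ccccc3)c(Sc3ccc(Cl)c(Cl)c3)nc2c1`, gives 32400 nM.
Compound 2, `COc1ccc(Sc2nc3cc(N)cc(N)c3nc2-c2ccccc2)cc1`, reaches only a limit, < 100000 nM.

Among the two numbers, compound 3 holds the higher one, with compound 1 nearest: the step of a 1.4-fold higher number from compound 1 to compound 3 (0.14 log units; within the scatter) stays within the scatter. The steps a step that the limit leaves unreadable from compound 1 to compound 2 and a step that the limit leaves unreadable from compound 2 to compound 3 cannot be sized because of the limit of < 100000 nM in this assay, at which 1 of the 3 values shown sits.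

Compound 4, `Nc1cc(N)c2nc(-c3ccccc3)c(Oc3ccc(F)cc3)nc2c1`, differs from compound 3 in one place: 4-fluorophenoxy in place of (3,4-dichlorophenyl)sulfanyl on an aromatic carbon. Among the measured compounds shown here, no measured step swaps one sulfur-linked aryl for an oxygen-linked one, so the only guide is that compound 1 and compound 3, with quite different groups at this position, sit within the scatter of each other, as a 1.4-fold higher number from compound 1 to compound 3 (0.14 log units; within the scatter) shows. Compound 4 is therefore expected to stay close to compound 3, the step of a 1.1-fold lower number from compound 3 to compound 4 (0.03 log units; within the scatter) being the estimate, with no direction beyond the scatter. For compound 4 the expected value in this assay is 30000 nM, between 10000 nM and 100000 nM.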

Compound 4, concentration for 50% growth inhibition: 17000 nM
Compound 4: middle estimate off by 1.8-fold (0.25 log units), on the high side, and the stated range covers the measured number.
By their numbers in this assay, from the lowest: compounds 4, 1 and 3 (each within the scatter of the next).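

In this assay, the oxygen-linked 4-fluorophenoxy group at this aromatic carbon next to the ring nitrogen gives a result that cannot be told apart from those of the sulfur-linked and nitrogen-linked groups: the values show a 1.9-fold lower number from compound 3 to compound 4 (0.28 log units; within the scatter) and a 1.4-fold lower number from compound 1 to compound 4 (0.14 log units; within the scatter), and both steps stay within the scatter. The link atom and the ring substituents change together in these swaps, so neither change can be judged alone. The step from compound 2 to compound 4 cannot be read because compound 2 is recorded only as a limit: the limit of < 100000 nM in this assay, at which 1 of the 4 values shown sits.

From the compounds shown here alone, whether a morpholine or a carboxylic acid at this carbon, with no aryl group attached, would move the number beyond the scatter stays open. Also open is what replacing the phenyl group, shared by all the compounds shown, with a pyridine would do.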